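Cytotoxicity notes on a sulfonyl-linked series

The compounds below may be only part of what the source reports. "The series", "measured", "known", "first", "only" and "open" are said of these compounds alone.

Compound 1 `O=c1[nH]c2ccc(Cl)cc2n1S(=O)(=O)Cc1ccc(Cl)cc1`, compound 2 `Cc1ccccc1CS(=O)(=O)n1c(=O)[nH]c2ccc(Cl)cc21` and compound 3 `O=c1[nH]c2ccc(Cl)cc2n1S(=O)(=O)CCc1ccc(Cl)cc1` have been measured; compound 4 `Cc1ccccc1CCS(=O)(=O)n1c(=O)[nH]c2ccc(Cl)cc21` has not. In an ADME assay on MT4 cells (Homo sapiens) for cytotoxicity, read by MTT assay, with a stated time of 5 days (on this read-out lower numbers stand for higher toxicity in this test and higher numbers for lower toxicity in this test), compound 1 gives 77000 nM, compound 2 gives 238000 nM and compound 3 gives 91000 nM. The change 2-methylphenyl in place of 4-chlorophenyl on a saturated chain carbon bound to a sulfonyl sulfur produced a 3.1-fold higher number from compound 1 to compound 2 (0.49 log units; beyond the scatter). Compound 1 and compound 3 differ in more than one place, so the difference between the two cores is not broken down here; their values in this assay lie within the scatter of each other. The change 2-methylphenyl in place of 4-chlorophenyl on a saturated chain carbon, two bonds along the chain from a sulfonyl sulfur is the same kind of change, the place differing in that the saturated chain carbon is two bonds along the chain from the sulfonyl sulfur rather than bound to it. Compound 4 is expected to show a 3.0-fold higher number from compound 3 to compound 4 (0.47 log units; beyond the scatter), resting on a 3.1-fold higher number from compound 1 to compound 2 (0.49 log units; beyond the scatter). In this assay compound 4 is estimated at 270000 nM, between 130000 nM and 550000 nM.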

Compound 4, half-maximal cytotoxic concentration: 32000 nM
For compound 4 the middle estimate is 8.4-fold (0.93 log units) above the measured one; measured number below the stated range.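

In this assay, 2-methylphenyl in place of 4-chlorophenyl gives a 2.8-fold lower number from compound 3 to compound 4 (0.45 log units; beyond the scatter), so the direction of the change is not kept when it is carried from the core of compound 1 to the core of compound 3. The two steps differ by more than their scatter: the same change on two cores in this assay, a 3.1-fold higher number (0.49 log units; beyond the scatter) from compound 1 to compound 2 and a 2.8-fold lower number (0.45 log units; beyond the scatter) from compound 3 to compound 4, 8.8-fold (0.94 log units) apart, beyond the scatter of two such steps. This shows that the effect of the change in this assay cannot be transferred between these two cores, but with a single pair on each core it does not show why the steps differ or how other groups would behave.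

Still open, on these data alone, is whether 2-chlorophenyl or 4-methylphenyl would follow either step on these cores. Also open, as far as these compounds go, is what a longer chain on the sulfonyl sulfur would do to the step.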